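Neopentyl in place of phenyl on the shared core

The source may report more compounds than this note shows. Statements on the series, on what has been measured and on what is new or still open speak of the compounds shown alone.

In an ADME assay on liver for metabolic stability, with Liver microsome (Homo sapiens) as the target, read by LC-MS, using microsomes (a higher number here means faster removal of the compound, a lower number slower removal), compound 1 `CC(C)(C)OC[C@@H](O)C(=O)N1[C@H](C(=O)NCc2cc(Cl)ccc2-n2cnnn2)C[C@@H]2C[C@@H]21` comes in at 21 mL.min-1.g-1 and compound 2 `O=C(NCc1cc(Cl)ccc1-n1cnnn1)[C@@H]1C[C@H]2C[C@H]2N1C(=O)[C@H](O)CC1CC1` at 25 mL.min-1.g-1 on the same scale. Compound 3 `O=C(NCc1cc(Cl)ccc1-n1cnnn1)[C@@H]1C[C@H]2C[C@H]2N1C(=O)[C@H](O)c1ccccc1` reads < 15 mL.min-1.g-1 as a limit of the assay and not as a number. The measured step of an at least 1.6-fold lower number from compound 2 to compound 3 (0.22 log units; that floor lies within the scatter) is the one that bears on the change ahead, with phenyl in place of cyclopropylmethyl.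

Compound 4 `CC(C)(C)C[C@@H](O)C(=O)N1[C@@H]2C[C@@H]2C[C@H]1C(=O)NCc1cc(Cl)ccc1-n1cnnn1` differs from compound 3 through neopentyl in place of phenyl on a saturated chain carbon bound to a carbonyl carbon and an oxygen on a saturated carbon with neopentyl in place of phenyl on a saturated chain carbon bound to a carbonyl carbon and an oxygen on a saturated carbon. Without the phenyl, compound 4 is expected to resemble compound 2 at 25 mL.min-1.g-1 and compound 1 at 21 mL.min-1.g-1 more than compound 3, so a modest rise is expected, of a size that may not clear the scatter. The estimated change is an at least 1.6-fold higher number from compound 3 to compound 4 (0.20 log units; that floor lies within the scatter) in this assay for this swap. For compound 4 the estimated value is 24 mL.min-1.g-1 with 15 mL.min-1.g-1 to 40 mL.min-1.g-1 as the expected range.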

Compound 4, intrinsic clearance in microsomes: 71 mL.min-1.g-1
Compound 4: the middle estimate sits 3.0-fold (0.47 log units) below what was measured; the measured number lies above the stated range.
By their numbers in this assay, from the lowest: compounds 1 and 2 (each within the scatter of the next); then compound 4. At a limit, below all of these: compound 3.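

In this assay, going by these compounds alone, neopentyl in place of phenyl gives an at least 4.7-fold higher number from compound 3 to compound 4 (0.67 log units; beyond the scatter), which is the first step at this position to clear the scatter. The position also separates two side chains without a ring: tert-butyl in place of cyclopropyl gives a 2.8-fold higher number from compound 2 to compound 4 (0.45 log units; beyond the scatter), so compound 4 stands apart from compound 2 as well as from the phenyl compound. Compound 3 sits at a limit of the assay and not at a number, so its step is only a floor: the limit of < 15 mL.min-1.g-1 in this assay, at which 1 of the 4 values shown sits.

What lies behind the rise with neopentyl cannot be told from these compounds. As far as these compounds go, how a pyridine ring or a chain ending in a carboxylic acid would read at this position stays open, as does the true reading of compound 3.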